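Compound 4 in this assay: a furan-2-yl replacement

The source may report more compounds than this note shows. Statements on the series, on what has been measured and on what is new or still open speak of the compounds shown alone.

Compound 1 `COc1cccc(CNCCCNc2ccnc3cc(-c4ccc(C(F)(F)F)cc4)ccc23)c1O` gives 32000 nM in a physicochemical assay for solubility, with a stated time of 18 h, at pH 7.4 (a lower number here means a less soluble compound, a higher number a more soluble compound), the highest of the three numbers measured. Compound 2 `CCC(CC)c1ccc2c(NCCCNCc3cccc(OC)c3O)ccnc2c1` gives 4200 nM and compound 3 `COc1cccc(CNCCCNc2ccnc3cc(Cc4ccc(F)cc4)ccc23)c1O` gives 4200 nM in this assay. The measured steps, a 7.6-fold lower number from compound 1 to compound 2 (0.88 log units; beyond the scatter) and a 7.6-fold lower number from compound 1 to compound 3 (0.88 log units; beyond the scatter), both change the group on the aromatic carbon of the shared core, while no change at the digits printed from compound 2 to compound 3 (within the scatter). Compound 4 `FC(F)(F)c1ccc(-c2ccc3c(NCCCNCc4ccco4)ccnc3c2)cc1` differs from compound 1 elsewhere: furan-2-yl in place of 2-hydroxy-3-methoxyphenyl on a saturated chain carbon bound to an amine nitrogen. Among the measured compounds shown here, no measured step touches this position, so the direction is open; steps of the size seen so far are plausible. Compound 4 is therefore expected at 20000 nM, within 5000 nM to 80000 nM, and the expected step is a 1.6-fold lower number from compound 1 to compound 4 (0.20 log units; within the scatter).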

Compound 4, solubility: 32000 nM
Estimate against measurement, compound 4: 1.6-fold (0.20 log units) below; measured number inside the range.
By their numbers in this assay, from the lowest: compounds 2 and 3 (each within the scatter of the next); then compounds 1 and 4 (each within the scatter of the next).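

In this assay, among the compounds shown here, the change to furan-2-yl at this place, on a saturated chain carbon bound to an amine nitrogen, gives no change at the digits printed from compound 1 to compound 4 (within the scatter) and so provides the first reading at this position. The 2-hydroxy-3-methoxyphenyl group, with its hydrogen-bond donor, can therefore leave the compound 1 scaffold without a shift beyond the scatter. No available evidence explains this result.

As far as these compounds go, it remains open whether furan-2-yl reads the same alongside the pentan-3-yl of compound 2 or the 4-fluorobenzyl of compound 3. From the compounds shown here alone, how a carboxylic acid or a longer chain would read in this place also remains open.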